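The source may hold more compounds than are shown below. What is called first, only, known or untested is meant among the compounds shown, and "the series" means these compounds.

Measured so far, in an ADME assay on HEL cells (Homo sapiens) for cytotoxicity, with a stated time of 3 days; on this read-out lower numbers stand for higher toxicity in this test and higher numbers for lower toxicity in this test:
- compound 1 `Cc1cc(-c2ccccc2)cn2c(CSCCc3ccccc3)cnc12`: 31 ug/mL
- compound 2 `Cc1cc(-c2ccsc2)cn2c(CSCCc3ccccc3)cnc12`: a limit of the assay, > 50 ug/mL
- compound 3 `COc1ccc(-c2cc(C)c3ncc(CSCCc4ccccc4)n3c2)cc1`: 25.8 ug/mL

Compound 3 holds the lowest of the two plain numbers; its nearest neighbour is compound 1, and the step of a 1.2-fold lower number from compound 1 to compound 3 (0.08 log units; within the scatter) lies within the scatter. For compound 2 only a limit is recorded (the limit of > 50 ug/mL in this assay, at which 1 of the 3 values shown sits). The step of an at least 1.9-fold lower number from compound 2 to compound 3 (0.28 log units; that floor lies within the scatter) therefore has only a floor, and that floor lies within the scatter. So far, then, no measured pair in this assay is separated beyond the scatter.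

Compound 4 `Cc1cc(-c2cccc([N+](=O)[O-])c2)cn2c(CSCCc3ccccc3)cnc12` is not yet measured. It differs from compound 3 by 3-nitrophenyl in place of 4-methoxyphenyl on an aromatic carbon. Two measured steps change the same pendant ring: an at least 1.6-fold higher number from compound 1 to compound 2 (0.20 log units; that floor lies within the scatter), a floor inside the scatter, and the methoxy step already named, also inside the scatter. Neither exchange of the pendant ring moved this assay beyond the scatter, and the nitro exchange is of the same kind. For compound 4 the expectation is therefore a step of a 1.2-fold higher number from compound 3 to compound 4 (0.07 log units; within the scatter) of no size beyond the scatter. Compound 4 is estimated at 30 ug/mL, between 15 ug/mL and 60 ug/mL.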

Compound 4, half-maximal cytotoxic concentration: 43 ug/mL
Beside the measured number, compound 4's estimate is 1.4-fold (0.16 log units) below it; the range from low to high includes it.
By their numbers in this assay, from the lowest: compounds 3, 1 and 4 (each within the scatter of the next). At a limit, above all of these: compound 2.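

In this assay, the exchange at this position, on an aromatic carbon two atoms from the ring nitrogen, again produces no separation, since a 1.7-fold higher number from compound 3 to compound 4 (0.22 log units; within the scatter) and a 1.4-fold higher number from compound 1 to compound 4 (0.14 log units; within the scatter). A 3-nitrophenyl group now joins phenyl and 4-methoxyphenyl at this place, and the plain numbers of compound 1, compound 3 and compound 4 all stay within the scatter of one another, so neither added group nor the shift from 4-methoxyphenyl to 3-nitrophenyl opens a gap. The step of an at least 1.1-fold lower number from compound 2 to compound 4 (0.06 log units; that floor lies within the scatter) gives only a floor, and its thiophen-3-yl end is a limit of the assay: the limit of > 50 ug/mL in this assay, at which 1 of the 4 values shown sits.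

As far as these compounds go, whether any group at this position can move this assay beyond the scatter remains open, for example an amine or a carboxylic acid on the pendant ring, or a saturated ring in its place. The compounds shown also leave open whether a shorter or longer chain on the other side of the shared core would change the picture, and whether the thiophen-3-yl compound truly differs from the others.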